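Ester in place of the amide on the side chain

The source may report more compounds than this note shows. Statements on the series, on what has been measured and on what is new or still open speak of the compounds shown alone.

Measured so far:
- compound 1, `CCOC(=O)C[C@H]1[C@@H](O[Si](C)(C)C(C)(C)C)[C@H](n2cnc3c(NC(=O)Nc4ccccc4)ncnc32)O[C@@H]1COC(=O)NC`: 7.7 nM
- compound 2, `CNC(=O)NC[C@H]1O[C@@H](n2cnc3c(NC(=O)Nc4ccccc4)ncnc32)[C@H](O[Si](C)(C)C(C)(C)C)[C@@H]1CC(=O)N(C)OC`: 12.3 nM

Both compounds were tested in a functional assay on COLO 205 cells (Homo sapiens) for antiproliferative activity; on this read-out lower numbers stand for stronger inhibition of growth and higher numbers for weaker inhibition of growth. Compound 2 has the higher of the two numbers, but its gap to compound 1 lies within the usual scatter, so the two cannot be told apart.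

Compound 3, `CCOC(=O)C[C@H]1[C@@H](O[Si](C)(C)C(C)(C)C)[C@H](n2cnc3c(NC(=O)Nc4ccccc4)ncnc32)O[C@@H]1CNC(=O)NC`, has not been measured. It is derived from compound 2 by one change: ethoxy in place of methoxy(methyl)amino on a carbonyl carbon. Among the measured compounds shown here, no step between measured compounds is available for this exact change. Compound 1, which itself carries an ethoxycarbonyl group, gives 7.7 nM in this assay, which suggests that an ethoxycarbonyl group at this position is compatible with strong inhibition. The step from compound 2 to compound 3 is therefore expected to be small, a 1.4-fold lower number from compound 2 to compound 3 (0.14 log units; within the scatter), in either direction and within the scatter. Compound 3 is expected to give about 9 nM, in a range from 4 nM to 20 nM.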

Compound 3, concentration for 50% growth inhibition: 3.84 nM
For compound 3 the middle estimate is 2.3-fold (0.37 log units) above the measured one; the measured number lies below the stated range.
By their numbers in this assay, from the lowest: compounds 3, 1 and 2 (each within the scatter of the next, the first and the last beyond it).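

In this assay, ethoxy in place of methoxy(methyl)amino on a carbonyl carbon gives a 3.2-fold lower number from compound 2 to compound 3 (0.51 log units; beyond the scatter), a modest step showing that the group on this carbonyl carbon can affect the read-out, which compound 1 and compound 2 could not show because they differ in more than one place. At the other place, (methylcarbamoyl)amino in place of (methylcarbamoyl)oxy on a saturated chain carbon bound to a saturated ring carbon gives a 2.0-fold lower number from compound 1 to compound 3 (0.30 log units; within the scatter), so these two groups cannot be told apart here. Nothing measured here accounts for either step.

Among the compounds shown here, only two groups on this carbonyl carbon can be compared, so how a carboxylic acid or a longer alkoxy chain would read there remains open. On these data alone, it also remains open whether the step from methoxy(methyl)amino to ethoxy would hold with (methylcarbamoyl)oxy at the other place.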